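This account rests on a few compounds, and the source may have more. Where it says the series, first, only, none or still open, it means among the compounds named here.

Measured in a functional assay on BGC-823 cells (Homo sapiens) for antiproliferative activity, read by MTT assay, with a stated time of 24 h; a lower number here means a stronger inhibitor, a higher number a weaker inhibitor:

- compound 1 `Sc1nnc(-c2ccc3c(c2)OCCO3)n1-c1ccccc1`: 47000 nM
- compound 2 `c1ccc(CSc2nnc(-c3ccc4c(c3)OCCO4)n2-c2ccccc2)cc1`: 73400 nM
- compound 3 `Cc1ccccc1CSc1nnc(-c2ccc3c(c2)OCCO3)n1-c1ccccc1`: > 100000 nM, a limit of the assay and not a number

Compound 3 has only a limit, not a number: it sits at the limit of > 100000 nM in this assay, at which 1 of the 3 values shown sits. Compound 4 `Brc1cccc(CSc2nnc(-c3ccc4c(c3)OCCO4)n2-c2ccccc2)c1` differs from it by 3-bromophenyl in place of 2-methylphenyl on a saturated chain carbon bound to a sulfur.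

Among the measured compounds shown here, three measured steps bear on this change. Benzyl in place of hydrogen on the sulfur gave a 1.6-fold higher number from compound 1 to compound 2 (0.19 log units; within the scatter). 2-Methylbenzyl in the same place gave an at least 2.1-fold higher number from compound 1 to compound 3 (0.32 log units; beyond the scatter). Methyl in place of hydrogen on an aromatic carbon gave an at least 1.3-fold higher number from compound 2 to compound 3 (0.13 log units; that floor lies within the scatter). For the measured compounds named here, all three are small, and none of the measured compounds carries bromine, so the data say nothing direct about that atom.

The closest guide is compound 2 at 73400 nM, the plain benzyl member, and compound 4 is expected to lie in its region of this assay. A modest move towards a lower number is therefore expected, although it may not clear the scatter. The estimated change is an at least 1.5-fold lower number from compound 3 to compound 4 (0.18 log units; that floor lies within the scatter), and it is measured against a limit. For compound 4 the estimate is 65000 nM, with an expected range from 30000 nM to 100000 nM.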

Compound 4, half-maximal inhibitory concentration: 65600 nM
Compound 4: middle estimate off by 1.0-fold (0.00 log units), on the low side, and the stated range covers the measured number.
By their numbers in this assay, from the lowest: compounds 1, 4 and 2 (each within the scatter of the next). At a limit, above all of these: compound 3.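

In this assay the change of 3-bromophenyl in place of 2-methylphenyl on a saturated chain carbon bound to a sulfur gave an at least 1.5-fold lower number from compound 3 to compound 4 (0.18 log units; that floor lies within the scatter) and so brought a readable number back to this position, which shows that a substituent on the benzyl ring does not of itself carry the value to a limit, although compound 3 does reach one and the floor of this step does not establish a real difference. A bromine added to the benzyl ring gave a 1.1-fold lower number from compound 2 to compound 4 (0.05 log units; within the scatter) and 3-bromobenzyl in place of hydrogen on the sulfur gave a 1.4-fold higher number from compound 1 to compound 4 (0.14 log units; within the scatter) so neither the bromine nor the whole 3-bromobenzyl group moves the number beyond the scatter. Among the compounds shown here, compound 3 remains the only compound with a limit of the assay and not a number: the limit of > 100000 nM in this assay, at which 1 of the 4 values shown sits.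

Still open, from the compounds shown here alone, is whether the result for compound 3 follows the methyl group or its place on the ring, as compound 3 and compound 4 differ in both the group and its place. Also open, going by these compounds, is how an amine, a carboxylic acid or a longer chain between the sulfur and the ring would read in this assay.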